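Plasma stability notes: double ester series, compound 4 outlook

A few compounds are considered here, and "the series" means these few. Any claim that something is new, unique, unknown or untested is made for them only; others in the source may bear on it.

Measured compounds in an ADME assay on a cell-free system (plasma, Rattus norvegicus) for metabolic stability, read by LC-MS, with a stated time of 60 min, at 37 degrees C, tested at 50 uM; on this read-out lower numbers stand for a less stable compound and higher numbers for a more stable compound:
compound 1 `C[C@@H](O)[C@H]1C(=O)N2C3=C(S[C@@H]4CN[C@@H](C4)C(=O)Nc4cccc(c4)C(=O)OCCCCOC3=O)[C@H](C)[C@H]12`: 0%
compound 2 `C[C@@H](O)[C@H]1C(=O)N2C(C(=O)OCc3oc(=O)oc3C(C)(C)C)=C(S[C@@H]3CN[C@H](C(=O)Nc4cccc(C(=O)OCc5oc(=O)oc5C(C)(C)C)c4)C3)[C@H](C)[C@H]12`: 0%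
compound 3 `COC(=O)OCOC(=O)C1=C(S[C@@H]2CN[C@H](C(=O)Nc3cccc(C(=O)OCOC(=O)OC)c3)C2)[C@H](C)[C@@H]2[C@@H]([C@@H](C)O)C(=O)N12`: 0%

In this assay compound 1 gives 0%, compound 2 gives 0% and compound 3 gives 0%. Compound 3 thus stands level with compounds 1 and 2 at the digits read; the gaps to both are within the usual scatter, so no order among the three is claimed. For the measured compounds named here, none of the measured pairs differs in one place only, so no measured step of known size exists in this set.

Compound 4 `COC(=O)OCOC(=O)C1=C(S[C@@H]2CN[C@H](C(=O)Nc3cccc(C(=O)O)c3)C2)[C@H](C)[C@@H]2[C@@H]([C@@H](C)O)C(=O)N12` differs from compound 3 by hydrogen in place of ((methoxycarbonyl)oxy)methyl on an oxygen next to a carbonyl group. One (((methoxycarbonyl)oxy)methoxy)carbonyl group remains in compound 4, while the second becomes a carboxy group. Going by the values given here, compound 3 gives 0%, and no compound in this set gives a higher reading, so there is nothing in the measured values that points to a change of known size for compound 4. A small upward step is expected for compound 4, a number 5 percentage points higher from compound 3 to compound 4 (within the scatter), not clearly beyond the scatter. Compound 4 is estimated at 5%, in the range 0% to 30%.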

Compound 4, percent of the compound remaining: 0%
Compound 4: middle estimate off by 5 percentage points, on the high side, and the stated range covers the measured number.
By their numbers in this assay, from the lowest: compounds 1, 2, 3 and 4 (each within the scatter of the next).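

In this assay, for the compounds shown here, hydrogen in place of ((methoxycarbonyl)oxy)methyl on an oxygen next to a carbonyl group gives no change at the digits printed from compound 3 to compound 4 (within the scatter) as the first measured step in one place. With a carboxy group at one place, the one remaining (((methoxycarbonyl)oxy)methoxy)carbonyl group still goes with compound 4 at 0% and the reading does not separate it from compound 3. Nothing measured here accounts for this result.

Going by these compounds, whether a reading clear of this level appears with a carboxy group at both places, or with a simple ethyl ester in place of the remaining (((methoxycarbonyl)oxy)methoxy)carbonyl group, stays open. How quickly any of these compounds is lost before the end of the stated time also stays open.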